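From Thiophen-2-yl to Phenyl: An Expected Step

The source may hold more compounds than are shown below. What is called first, only, known or untested is meant among the compounds shown, and "the series" means these compounds.

Of the compounds shown here, three have been measured in a functional assay on MOLT-4 cells (Homo sapiens) for inhibition, read by sulforhodamine B assay, with a stated time of 48 h; a lower number here means a stronger inhibitor of growth, a higher number a weaker inhibitor of growth. Compound 1 `COc1ccc(-c2cc(-c3cccn3C)c(C#N)c(=O)[nH]2)cc1OC` gives 22900 nM. Compound 2 `CC1CCCc2c1nc(N)c(C#N)c2-c1cccn1C` reaches only a limit of the assay, > 100000 nM. Compound 3 `Cn1cccc1-c1cc(-c2cccs2)nc(N)c1C#N` likewise stops at a limit, > 100000 nM, so it stands at the limit of > 100000 nM in this assay, at which 2 of the 3 values shown sit, rather than at a number. Within the data shown here, no step between two measured compounds that differ in one place is available, and a pair of limits offers no comparison of size. Compound 4 `Cn1cccc1-c1cc(-c2ccccc2)nc(N)c1C#N` differs from compound 3 in one place: phenyl in place of thiophen-2-yl on an aromatic carbon. With nothing beyond the shared limit to build on, the expected change in this assay is a number no higher from compound 3 to compound 4 (the limit leaves the size open), in no direction beyond the scatter. Compound 4 is therefore estimated at 100000 nM, with a range from 40000 nM to 250000 nM, and quite possibly again only a limit.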

Compound 4, concentration for 50% growth inhibition: > 100000 nM
Compound 4 ended at the assay's limit; the forecaster's own chance of this, stated with the estimate: 70%; the middle value sits exactly at the limit.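

Compound 3 and compound 4 both stop at a limit, so no step can be read between them: the limit of > 100000 nM in this assay, at which 3 of the 4 values shown sit.

The compounds shown leave open whether any other group in this place on the shared core would give a readable number.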